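Notes on the step from compound 3 to compound 4

A few compounds are considered here, and "the series" means these few. Any claim that something is new, unique, unknown or untested is made for them only; others in the source may bear on it.

In a physicochemical assay for solubility, using the shake flask method, in simulated intestinal fluid, measured as kinetic solubility, with a stated time of 2 h, at 25 degrees C, at pH 6.5 (on this read-out higher numbers stand for higher solubility and lower numbers for lower solubility), compound 1 (`Cc1noc(-c2nc(C)c3c(c2N)C(=O)N(CC2CCNCC2)C3=O)n1`) gives 160000 nM. Compound 2 (`COc1ccc(CN2C(=O)c3c(C)nc(-c4nc(C)no4)c(N)c3C2=O)cc1`) gives < 5000 nM, which is a limit. Compound 3 (`COc1cccc(CN2C(=O)c3c(C)nc(-c4nc(C)no4)c(N)c3C2=O)c1`) gives < 5000 nM, also a limit, so it has no exact standing.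

Compound 4 (`Cc1noc(-c2nc(C)c3c(c2N)C(=O)N(Cc2ccccc2F)C3=O)n1`) has 2-fluorophenyl in place of 3-methoxyphenyl on a saturated chain carbon bound to an amide-type nitrogen in a ring. Two large steps, beyond the scatter, bear on this: an at least 32-fold lower number from compound 1 to compound 2 (1.50 log units; beyond the scatter) and an at least 32-fold lower number from compound 1 to compound 3 (1.50 log units; beyond the scatter). Both replace piperidin-4-yl, which compound 4 also lacks. The step that the two limits leave unreadable from compound 2 to compound 3 gives no size. No step beyond the scatter is therefore expected in this assay, and another limit is likely. The expected change is a step that the limit leaves unreadable from compound 3 to compound 4. Compound 4 is estimated at 3000 nM, with an expected range of 800 nM to 6000 nM.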

Compound 4, solubility: < 5000 nM
Compound 4: only a limit was reported; the forecaster's own chance of this, stated with the estimate: 85%; the middle value is on the limit's open side.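

In this assay compound 4 gives < 5000 nM, which is a limit. The replacement of piperidin-4-yl by 2-fluorophenyl gives an at least 32-fold lower number from compound 1 to compound 4 (1.50 log units; beyond the scatter), so this position now shows the same outcome with a phenyl group carrying fluorine as with those carrying methoxy. The steps among compound 2, compound 3 and compound 4 cannot be read, and the limit dominates the set: the limit of < 5000 nM in this assay, at which 3 of the 4 values shown sit.

Any order among these three phenyl groups stays open. Also open, on these data alone, is what an open-chain amine or a carboxylic acid would give at this place.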